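Growing the Amide Nitrogen Substituent in a Pyrazole Series

The source may report more compounds than this note shows. Statements on the series, on what has been measured and on what is new or still open speak of the compounds shown alone.

Measured so far in a functional assay on the whole organism (strain Wistar) for inhibition, with Rattus norvegicus as the target, read by paw edema, with stated times of 30 min and 3 h, at a dose of 100 mg/kg by the oral route; on this read-out higher numbers stand for more inhibition at the one dose given (going by the name of the read-out) and lower numbers for less inhibition:
Compound 1 `COc1cc(C(N)=O)nn1-c1ccccc1` gives 34.3%.
Compound 2 `CNC(=O)c1cc(OC)n(-c2ccccc2)n1` gives 57.9%.
Compound 3 `COc1cc(C(=O)N2CCCCC2)nn1-c1ccccc1` gives 28.2%.

All three share one core and differ only in the group on the carbonyl carbon. Compound 2 stands highest of the three numbers in this assay : the change a number 23.6 percentage points higher from compound 1 to compound 2 (beyond the scatter) and the change a number 29.7 percentage points lower from compound 2 to compound 3 (beyond the scatter) both lie beyond the scatter. Compound 1 and compound 3 sit close together, since the change a number 6.1 percentage points lower from compound 1 to compound 3 (within the scatter) lies within the scatter.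

Compound 4 `COc1cc(C(=O)N(C)c2ccc(C)cc2)nn1-c1ccccc1` has not yet been tested. Compared with compound 2 it carries 4-methylphenyl in place of hydrogen on an amide-type nitrogen. Among the compounds with values here, the step that bears most directly on this is the one from compound 2 to compound 3, where the methylamino group on the carbonyl carbon gave way to piperidin-1-yl and the number fell, a number 29.7 percentage points lower from compound 2 to compound 3 (beyond the scatter). Building further onto the same nitrogen in compound 4 is expected to move the number in the same direction, giving an estimated step of a number 25.9 percentage points lower from compound 2 to compound 4 (beyond the scatter) in this assay . Compound 4 is therefore expected to show about 32%, with a likely range from 15% to 50%.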

Compound 4, a percentage reported as inhibition, in the whole organism at one dose (the size of the read-out at that dose, not a potency): 22.3%
Beside the measured number, compound 4's estimate is 9.7 percentage points above it; the range from low to high includes it.
By their numbers in this assay, from the lowest: compounds 4, 3 and 1 (each within the scatter of the next, the first and the last beyond it); then compound 2.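

Replacing the amide hydrogen with 4-methylphenyl while the methyl stays on that nitrogen gives a number 35.6 percentage points lower from compound 2 to compound 4 (beyond the scatter) in this assay, so the methyl alone does not carry the higher number, a point compound 3 could not show since its piperidin-1-yl group removes both the methyl and the hydrogen. Among these four compounds, the high number appears only with one methyl and one hydrogen on the nitrogen, as in compound 2, while compound 1 goes against any simple link to the amide hydrogen, since it has hydrogens there and still stands well under compound 2. No measurement offered here explains why the number falls at this position.

The compounds shown cannot separate the loss of the amide hydrogen from the arrival of a larger group, as both happen together in the step to compound 4. A dimethylamino group on the carbonyl carbon would remove the hydrogen while adding only one carbon, and an ethylamino group would keep the hydrogen while lengthening the chain, so either would help to tell these two changes apart.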